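The source may hold more compounds than are shown below. What is called first, only, known or untested is meant among the compounds shown, and "the series" means these compounds.

Working notes on the series. The three measured compounds share one core and differ only in the group on the carbonyl carbon. Compound 1 `C#CCNC(=O)c1ccc(C(CC)(CC)c2ccc(OCC(O)C(C)(C)C)c(C)c2)n1CC` gives 240 nM in an assay on HL-60 cells for agonist activity at vitamin D3 receptor (Homo sapiens), read by microscopy, with a stated time of 96 h; a lower number here means that less compound is needed, a higher number that more compound is needed for the effect. Compound 2 `C=CCN(C)C(=O)c1ccc(C(CC)(CC)c2ccc(OCC(O)C(C)(C)C)c(C)c2)n1CC` gives 3950 nM in this assay. Compound 3 `CCn1c(C(=O)N(CCC#N)CCC#N)ccc1C(CC)(CC)c1ccc(OCC(O)C(C)(C)C)c(C)c1` gives 97 nM in this assay, the lowest of the three numbers. The steps of a 2.5-fold lower number from compound 1 to compound 3 (0.39 log units; beyond the scatter) and a 41-fold lower number from compound 2 to compound 3 (1.61 log units; beyond the scatter) both lie beyond the scatter, so compound 3 is the most potent of the measured set. The largest single change seen so far is a 16-fold higher number from compound 1 to compound 2 (1.22 log units; beyond the scatter).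

Compound 4 `CC[C@@H](C)[C@H](NC(=O)c1ccc(C(CC)(CC)c2ccc(OCC(O)C(C)(C)C)c(C)c2)n1CC)C(=O)O` differs from compound 3 in one place: a group of 9 heavy atoms (6 carbon, 1 nitrogen, 2 oxygen; no ring) in place of a group of 9 heavy atoms (6 carbon, 3 nitrogen; no ring), on a carbonyl carbon. The measured steps that bear on this are those that also exchange the group on the carbonyl carbon, the modest step from compound 1 to compound 3 and the large step from compound 2 to compound 3. Neither of these, nor the step between compound 1 and compound 2, introduces a group with hydrogen-bond donors, so the direction for compound 4 is not fixed by the data, and a step of either sign beyond the scatter is possible. As a working figure, a modest rise is expected, a 3.1-fold higher number from compound 3 to compound 4 (0.49 log units; beyond the scatter). Compound 4 is therefore estimated at 300 nM in this assay, with a range from 60 nM to 1500 nM.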

Compound 4, half-maximal effective concentration: 2.3 nM
For compound 4 the middle estimate is 130-fold (2.12 log units) above the measured one; measured number below the stated range.
By their numbers in this assay, from the lowest: compound 4; then compound 3; then compound 1; then compound 2.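

The group on the carbonyl carbon can move the number in this assay much further than the earlier exchanges showed: (1-carboxy-2-methylbutyl)amino in place of the dinitrile-bearing group gives a 42-fold lower number from compound 3 to compound 4 (1.63 log units; beyond the scatter), although both groups hold the same count of heavy atoms, so that count alone does not set the result here. Against the other two groups the same change gives a 100-fold lower number from compound 1 to compound 4 (2.02 log units; beyond the scatter) and a 1700-fold lower number from compound 2 to compound 4 (3.23 log units; beyond the scatter), which places the entering group ahead of all three earlier groups, and the comparison with compound 1 shows that the gain also appears when the amide hydrogen is present on both sides of the step. No measurement at hand bears on why this group stands so far ahead.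

The compounds shown leave open whether the gain goes with the carboxylic acid or with the branched carbon chain, and a methyl ester of the same group and a plain carboxymethyl group on the amide-type nitrogen would separate the two. The weight of the 2 defined stereocentres also stays open, with no other stereoisomer of this group among the compounds shown.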